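This account rests on a few compounds, and the source may have more. Where it says the series, first, only, none or still open, it means among the compounds named here.

Of the compounds shown here, two of the shared core have been tested so far. Compound 1 `O=C1/C(=C/c2cccc(F)c2)CN(S(=O)(=O)c2ccc(C(F)(F)F)cc2)C/C1=C\c1cccc(F)c1` gives 18000 nM in an ADME assay on L02 cells (Homo sapiens) for cytotoxicity, read by MTT assay, with a stated time of 24 h; on this read-out lower numbers stand for stronger inhibition and higher numbers for weaker inhibition. Compound 2 `O=C1/C(=C/c2cccc(F)c2)CN(S(=O)(=O)c2ccc(F)cc2)C/C1=C\c1cccc(F)c1` gives 21900 nM in this assay, which is the higher of the two numbers, although the step of a 1.2-fold higher number from compound 1 to compound 2 (0.09 log units; within the scatter) shows that the two compounds cannot be told apart on this read-out. Compound 3 `CC(=O)Nc1ccc(S(=O)(=O)N2C/C(=C\c3cccc(F)c3)C(=O)/C(=C/c3cccc(F)c3)C2)cc1` differs from compound 2 by one change, (acetamido in place of fluoro on an aromatic carbon). Within the data shown here, the only measured step that bears on this change is a 1.2-fold higher number from compound 1 to compound 2 (0.09 log units; within the scatter), which exchanged a group at the same place and moved the number very little. Among the measured compounds shown here, no compound with an acetamido group has been measured, so there is no direct guide; the single available step gives no reason to expect a large move. Compound 3 is therefore expected to show a 1.0-fold higher number from compound 2 to compound 3 (0.00 log units; within the scatter). Compound 3 is estimated at 22000 nM, with a range from 9000 nM to 50000 nM.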

Compound 3, half-maximal inhibitory concentration: 17500 nM
Compound 3: middle estimate off by 1.3-fold (0.10 log units), on the high side; the measured number falls inside the stated range.
By their numbers in this assay, from the lowest: compounds 3, 1 and 2 (each within the scatter of the next).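

At this place, on an aromatic carbon para to a large group, acetamido brings in a hydrogen-bond donor and a hydrogen-bond acceptor that fluoro lacks, yet this assay does not separate the compounds: the move is a 1.3-fold lower number from compound 2 to compound 3 (0.10 log units; within the scatter), and against trifluoromethyl it is a 1.0-fold lower number from compound 1 to compound 3 (0.01 log units; within the scatter). Among these compounds, three different groups at this place, including one with more heavy atoms than fluoro, now give numbers within the scatter of one another, which is a wider test of the position than the single step from trifluoromethyl to fluoro could offer. No measurement shown here accounts for this flat result.

Going by these compounds, it remains open whether an amine, a carboxylic acid or a longer chain at this place would move the number beyond the scatter. On these data alone, it is also open whether the same flat result would hold on a core changed elsewhere.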